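The source may hold more compounds than are shown below. What is called first, only, known or untested is meant among the compounds shown, and "the series" means these compounds.

Working notes on a small set of analogues tested in a functional assay on HCT-15 cells (Homo sapiens) for inhibition, read by sulforhodamine B assay, with a stated time of 48 h, tested at 10 uM; a lower number here means less inhibition, a higher number more inhibition at the concentration tested (going by the name of the read-out). Compound 1 `O=Cc1ccc(-c2cn3ccnc3c(-c3ccc4ncn(C5CCCCC5)c4c3)n2)cc1` gives 49.1% in this assay. Compound 2 `O=Cc1ccc(-c2cn3ccnc3c(-c3ccc4ncn(Cc5ccccc5)c4c3)n2)cc1` differs from compound 1 by benzyl in place of cyclohexyl on an aromatic nitrogen; in this assay compound 2 gives 49.1%, and the step of no change at the digits printed from compound 1 to compound 2 (within the scatter). Compound 3 `c1cn2cc(-c3ccc4c(c3)ncn4C3CCCCC3)nc(-c3ccc4ncn(C5CCCCC5)c4c3)c2n1` carries a different core; the difference between the core of compound 3 and the core of compound 1 is not broken down here. In this assay compound 3 gives 35.6%, which is the lowest of the three numbers and lies beyond the scatter from both compound 1 and compound 2.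

Compound 4 `c1ccc(Cn2cnc3ccc(-c4nc(-c5ccc6c(c5)ncn6C5CCCCC5)cn5ccnc45)cc32)cc1` has not yet been measured in this assay. It differs from compound 3 by benzyl in place of cyclohexyl on an aromatic nitrogen, the same change that separates compound 2 from compound 1, with the place described in the same words in both cases. The change occurs twice among the compounds shown and has been measured once. Because the measured step of no change at the digits printed from compound 1 to compound 2 (within the scatter) shows no movement within the scatter, the corresponding step here is expected to be small as well, a number 0.4 percentage points higher from compound 3 to compound 4 (within the scatter). This expectation rests on a single measured pair on a different core, so the uncertainty is taken broader than the scatter alone. Compound 4 is therefore estimated to give 36% in this assay, within a range from 20% to 52%.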

Compound 4, a percentage reported as inhibition, at one concentration (the size of the read-out at that concentration, not a potency): -9.03%
Compound 4: the middle estimate sits 45 percentage points above what was measured; measured number outside the range, below it.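

In this assay, benzyl in place of cyclohexyl on an aromatic nitrogen does not behave as a transferable change between the core of compound 1 and the core of compound 3: the same change on two cores in this assay, no change at the digits printed (within the scatter) from compound 1 to compound 2 and a number 44.6 percentage points lower (beyond the scatter) from compound 3 to compound 4, 44.6 percentage points apart, beyond the scatter of two such steps. The large step on the second core, a number 44.6 percentage points lower from compound 3 to compound 4 (beyond the scatter), shows that the outcome of this change in the series depends on the core that carries it, so a flat result on one core cannot be taken as a guide to another. It does not show which feature of the two cores makes the difference, and with a single pair on each core and one concentration per compound, it gives no general rule for a third core or any information on potency.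

The compounds shown leave open whether the steep step on the core of compound 3 is specific to benzyl or would also appear with other groups on that aromatic nitrogen, since only cyclohexyl and benzyl occur there. A methyl, a longer alkyl chain or a chain ending in an amine or a carboxylic acid at the same place on both cores would help to separate these possibilities.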